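Swapping a propyl chain for a methoxyphenyl ring

A few compounds are considered here, and "the series" means these few. Any claim that something is new, unique, unknown or untested is made for them only; others in the source may bear on it.

Measured so far:
Compound 1 `COc1ccc(-c2cc(NNC(=O)Nc3cc(Cl)nc(Cl)c3)nc3c2cnn3C)cc1`: 520 nM
Compound 2 `Cc1nn(C)c2nc(NNC(=O)Nc3cc(Cl)nc(Cl)c3)cc(C3CC3)c12`: 3650 nM
Compound 3 `CCCc1cc(NNC(=O)Nc2cc(Cl)nc(Cl)c2)nc2c1c(C)nn2C`: 2360 nM

These three compounds were tested in an assay on isolated protein for binding affinity to sphingosine 1-phosphate receptor 2 (Homo sapiens), read by surface plasmon resonance; on this read-out lower numbers stand for tighter binding and higher numbers for weaker binding. Compound 3 gives 2360 nM, the second highest of the three numbers. Its closest neighbour is compound 2 at 3650 nM; the step of a 1.5-fold lower number from compound 2 to compound 3 (0.19 log units; within the scatter) sits within the scatter. Compound 1 stands furthest away at 520 nM, a clearly lower number that lies beyond the scatter.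

Compound 4 `COc1ccc(-c2cc(NNC(=O)Nc3cc(Cl)nc(Cl)c3)nc3c2c(C)nn3C)cc1` is the unmeasured compound. It differs from compound 3 in one place: 4-methoxyphenyl in place of propyl on an aromatic carbon. Among the measured compounds shown here, no measured step covers this exact change; the one measured step, a 1.5-fold lower number from compound 2 to compound 3 (0.19 log units; within the scatter), concerns a different swap of small groups. What can be said is that compound 1, which also carries a 4-methoxyphenyl group, gives 520 nM, while the two compounds with small alkyl groups give higher numbers. On that basis a lower number is expected for compound 4, roughly the step of a 3.6-fold lower number from compound 3 to compound 4 (0.56 log units; beyond the scatter), in this assay. The estimate for compound 4 is 650 nM, with a range from 250 nM to 1700 nM.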

Compound 4, dissociation constant: 1020 nM
Compound 4: the middle estimate sits 1.6-fold (0.20 log units) below what was measured; the range from low to high includes it.
By their numbers in this assay, from the lowest: compounds 1 and 4 (each within the scatter of the next); then compounds 3 and 2 (each within the scatter of the next).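

At this aromatic carbon, opposite the ring nitrogen, the core accepts a group with a whole aromatic ring: in this assay, exchanging propyl for 4-methoxyphenyl gives a 2.3-fold lower number from compound 3 to compound 4 (0.36 log units; beyond the scatter), and exchanging cyclopropyl for it gives a 3.6-fold lower number from compound 2 to compound 4 (0.55 log units; beyond the scatter). Both steps are modest but lie beyond the scatter, so with the methyl-bearing core held constant, the 4-methoxyphenyl group binds more tightly than either small group. The methyl-for-hydrogen change elsewhere on the core gives a 2.0-fold higher number from compound 1 to compound 4 (0.29 log units; within the scatter), which lies within the scatter, so no effect of that methyl can be claimed.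

Nothing shown explains why the 4-methoxyphenyl compound gives the lower number. Going by these compounds, it remains open how a plain phenyl ring or a 4-hydroxyphenyl ring would compare at this position, and so whether the ring alone or its methoxy group accounts for the step.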